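Methoxy Added to the Oxindole Ring of Compound 1

This account rests on a few compounds, and the source may have more. Where it says the series, first, only, none or still open, it means among the compounds named here.

Compound 1 `COc1c(/C=C2/C(=O)Nc3ccccc32)c2ccccc2n1-c1ccccc1` is the stronger of the two measured compounds: in a functional assay on NSCLC cells (Homo sapiens) for cytotoxicity, with a stated time of 48 h (a lower number here means a stronger inhibitor of growth, a higher number a weaker inhibitor of growth), compound 1 gives 8320 nM, while compound 2 `O=C1Nc2ccccc2/C1=C\c1c(Cl)n(CCCc2ccccc2)c2ccccc12` gives 72400 nM in this assay, a gap that lies beyond the usual scatter. The two differ at several places at once, so no single change can be tied to that gap. Compound 3 `COc1ccc2c(c1)/C(=C\c1c(OC)n(-c3ccccc3)c3ccccc13)C(=O)N2` has not been measured. It differs from compound 1 by methoxy in place of hydrogen on an aromatic carbon, a methoxy in place of hydrogen on an aromatic carbon, meta to one fused ring and para to the other. Going by the values given here, no pair of measured compounds shows the effect of such a change, so the direction is open. Compound 3 is expected to give 6000 nM in this assay, within 2000 nM to 20000 nM. The step of a 1.4-fold lower number from compound 1 to compound 3 (0.14 log units; within the scatter) is thus estimated to stay within the scatter.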

Compound 3, concentration for total growth inhibition: 17400 nM
Compound 3: the middle estimate sits 2.9-fold (0.46 log units) below what was measured; low and high end bracket the measured number.
By their numbers in this assay, from the lowest: compound 1; then compound 3; then compound 2.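

In this assay, going by these compounds alone, this is the first pair that differs in one place, and it gives this position a direction: methoxy in place of hydrogen on an aromatic carbon, meta to one fused ring and para to the other, brings a 2.1-fold higher number from compound 1 to compound 3 (0.32 log units; beyond the scatter), a modest loss of growth inhibition. The earlier compounds shown here could tie no gap to any single change, whereas this shift belongs to this one replacement. No available measurement accounts for the shift.

The compounds shown leave open whether a hydroxy group, an amine or a longer alkoxy chain on this same carbon would move the number further or bring it back. They also leave open whether methoxy on another carbon of this ring would act alike, and whether the step would carry over to compound 2, which differs from compound 1 at several places.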